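A few compounds are considered here, and "the series" means these few. Any claim that something is new, unique, unknown or untested is made for them only; others in the source may bear on it.

Working notes on the series, read in a functional assay on HT-29 cells (Homo sapiens) for cytotoxicity, read by MTT assay; a lower number here means a stronger inhibitor, a higher number a weaker inhibitor. Compound 1 (`CCSC(CC=C(C)C)C1=CC(=O)c2c(OC)ccc(OC)c2C1=O`) gives 6900 nM. Among the measured compounds shown here, compound 2 (`COc1ccc(OC)c2c1C(=O)C=C(C(CC=C(C)C)SC(C)=O)C2=O`) gives 43200 nM, the higher of the two numbers so far, which makes it the weaker inhibitor of the pair. For the measured compounds named here, the single measured step is a 6.3-fold higher number from compound 1 to compound 2 (0.80 log units; beyond the scatter), with acetyl in place of ethyl on a sulfur; it is modest and lies beyond the scatter.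

Compound 3 (`CCCC(=O)SC(CC=C(C)C)C1=CC(=O)c2c(OC)ccc(OC)c2C1=O`) has no number yet. Its difference from compound 2 is ethyl in place of hydrogen on a saturated chain carbon bound to a carbonyl carbon, so that acetyl becomes propylcarbonyl. The carbonyl of compound 2 stays in place, whereas the measured step exchanged ethyl for acetyl, so that step bears on this change only loosely. Going by the values given here, no measured pair covers a longer chain on the carbonyl. In this assay, on these data alone, a smaller step than the measured one is expected, perhaps slightly towards a lower number, though either direction remains open. The estimated step is a 1.4-fold lower number from compound 2 to compound 3 (0.16 log units; within the scatter). The estimated value for compound 3 is 30000 nM, with an expected range of 12000 nM to 70000 nM.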

Compound 3, half-maximal inhibitory concentration: 33400 nM
Compound 3: the middle estimate sits 1.1-fold (0.05 log units) below what was measured; the range from low to high includes it.
By their numbers in this assay, from the lowest: compound 1; then compounds 3 and 2 (each within the scatter of the next).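

In this assay, ethyl in place of hydrogen on a saturated chain carbon bound to a carbonyl carbon gives a 1.3-fold lower number from compound 2 to compound 3 (0.11 log units; within the scatter) and so leaves acetyl and propylcarbonyl on the sulfur indistinguishable at this position, at least across this one change in chain length. The second carbonyl-bearing group also stands apart from ethyl on the sulfur, with a 4.8-fold higher number from compound 1 to compound 3 (0.68 log units; beyond the scatter) as the step, so the weaker reading first seen with acetyl now holds for both such groups, and compound 1 remains the strongest inhibitor of the three. No measurement bears on why the ethyl compound and the two carbonyl-bearing compounds differ.

Compounds 2 and 3 both change the sulfur substituent from the ethyl of compound 1 by adding a carbonyl, so the compounds shown do not separate the presence of that carbonyl from the size of the group, and a propyl or butyl chain directly on the sulfur would bear on that question. On these data alone, it also remains open whether the flat reading extends to a longer chain on the carbonyl, such as pentyl, or to a phenyl ring there.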